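Swapping the benzyl group for a hydroxypropyl chain

The source may report more compounds than this note shows. Statements on the series, on what has been measured and on what is new or still open speak of the compounds shown alone.

Compound 1 `COc1cccc(Cn2cc(-c3ccc(C(F)(F)F)cc3)nn2)c1` and compound 2 `FC(F)(F)c1ccc(-c2cn(Cc3ccccc3)nn2)cc1` share one core and differ only in the methoxy group. In a functional assay on B16 cells (Mus musculus) for cytotoxicity, read by MTT assay, with a stated time of 48 h (a higher number here means a weaker inhibitor, a lower number a stronger inhibitor), compound 1 gives 17400 nM. Compound 2 reaches only the limit of this measurement, > 100000 nM, so its true value is not known. The step of an at least 5.7-fold higher number from compound 1 to compound 2 (0.75 log units; beyond the scatter) is therefore set by the limit of > 100000 nM in this assay, at which 1 of the 2 values shown sits, and compound 2 stands at the weak end of what has been measured. Compound 3 `OCCCn1cc(-c2ccc(C(F)(F)F)cc2)nn1` differs from compound 2 by 2-hydroxyethyl in place of phenyl on a saturated chain carbon bound to an aromatic nitrogen. Going by the values given here, none of the measured steps touches this place, since the only one, an at least 5.7-fold higher number from compound 1 to compound 2 (0.75 log units; beyond the scatter), concerns the methoxy group on the aromatic ring, so no direction can be drawn from it. Compound 3 is expected to remain weak, with an estimated 100000 nM in this assay, ranging from 30000 nM to 300000 nM. The expected step of a number no higher from compound 2 to compound 3 (the limit leaves the size open) is thus estimated to lie within the scatter.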

Compound 3, half-maximal inhibitory concentration: > 100000 nM
Compound 3: no number, only a limit; the forecaster's own chance of this, stated with the estimate: 60%; the middle value lies on the limit itself.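

In this assay, compound 3 gives > 100000 nM, which is a limit and not a number. The step from compound 2 to compound 3 cannot be read, so swapping benzyl for 3-hydroxypropyl has no measurable size here, and this position now shows two very different groups that the assay cannot tell apart: the limit of > 100000 nM in this assay, at which 2 of the 3 values shown sit. The one readable step with the new compound is an at least 5.7-fold higher number from compound 1 to compound 3 (0.75 log units; beyond the scatter) and it leaves compound 1, with its 3-methoxyphenyl group, as the only compound shown that gives a number at this position.

From the compounds shown here alone, whether an amine or a carboxylic acid in place of the hydroxyl, or a longer chain, would give a readable number remains open. Also open, going by these compounds, is how far apart the true values of compound 2 and compound 3 lie.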